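Swapping phenoxy for dimethylcarbamoyl on a shared core

The source may report more compounds than this note shows. Statements on the series, on what has been measured and on what is new or still open speak of the compounds shown alone.

compound 1 `Cc1ccc(-c2nc3cccnc3n2C2CCCCC2)cc1` gives 7000 nM
compound 2 `COc1ccc(-c2nc3cccnc3n2C2CCCCC2)cc1` gives 112 nM
compound 3 `c1ccc(Oc2ccc(-c3nc4cccnc4n3C3CCCC3)cc2)cc1` gives > 10000 nM

In a functional assay on MDA-MB-231 cells (Homo sapiens) for cytotoxicity, read by MTT assay, with a stated time of 24 h (on this read-out lower numbers stand for stronger inhibition and higher numbers for weaker inhibition), compound 3 reaches only a limit of the assay (> 10000 nM) and no number. Compound 4 `CN(C)C(=O)c1ccc(-c2nc3cccnc3n2C2CCCC2)cc1` changes one group of compound 3 (dimethylcarbamoyl in place of phenoxy on an aromatic carbon) and has not yet been measured. Within the data shown here, only one measured step offers guidance, and it concerns different groups: methoxy in place of methyl gave a 63-fold lower number from compound 1 to compound 2 (1.80 log units; beyond the scatter) and was large. It shows that one small swap can move this read-out strongly, but it cannot fix the direction here. A moderate move towards lower numbers is expected, an estimated step of an at least 4.0-fold lower number from compound 3 to compound 4 (0.60 log units; beyond the scatter) in this assay for now. For compound 4 the estimated value is 2500 nM (expected range 300 nM to 10000 nM).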

Compound 4, half-maximal inhibitory concentration: 520 nM
Estimate against measurement, compound 4: 4.8-fold (0.68 log units) above; the measured number falls inside the stated range.
By their numbers in this assay, from the lowest: compound 2; then compound 4; then compound 1. At a limit, above all of these: compound 3.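

In this assay, dimethylcarbamoyl in place of phenoxy on an aromatic carbon gives an at least 19-fold lower number from compound 3 to compound 4 (1.28 log units; beyond the scatter), so on the cyclopentyl-bearing core this position can carry a swap of large effect. Compound 3 stands at a limit, not at a number, so the true size of this step remains unknown: the limit of > 10000 nM in this assay, at which 1 of the 4 values shown sits.

The swap removes a ring and brings in a carbonyl and a nitrogen at once, so these two compounds cannot show which part of the change matters. On these data alone, what an amine or a carboxylic acid would give at this place also remains open.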